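The source may hold more compounds than are shown below. What is called first, only, known or untested is meant among the compounds shown, and "the series" means these compounds.

In a functional assay on HEL cells (Homo sapiens) for cytotoxicity (a higher number here means that more compound is tolerated, a lower number that less compound is tolerated), compound 1 `CCCCCCC#Cc1cc2cn([C@@H]3O[C@H](CO)[C@@H](O)[C@H]3O)c(=O)nc2o1` gives > 133000 nM as a limit, so it has no numerical place in the series. Compound 2 `CCCCCCC#Cc1cc2cn([C@@H]3O[C@H](CO)[C@@H](O)[C@@H]3O)c(=O)nc2o1` gives > 53000 nM as a limit too. Compound 3 `CCCCCCC#Cc1cc2cn(C)c(=O)nc2o1` also gives > 194000 nM as a limit. For the measured compounds named here, no compound can therefore be ranked against another.

Compound 4 `CCCCCCCCC#Cc1cc2cn([C@@H]3O[C@H](CO)[C@@H](O)[C@H]3O)c(=O)nc2o1` differs from compound 1 only by ethyl in place of hydrogen on a saturated chain carbon, six bonds along the chain from a triple-bonded carbon and leaves the rest of the structure unchanged. Three measured steps are available: a step that the two limits leave unreadable from compound 1 to compound 2 and a step that the two limits leave unreadable from compound 1 to compound 3 and a step that the two limits leave unreadable from compound 2 to compound 3 but none of them alters the chain, and none has a readable size. Compound 1 and its limit of > 133000 nM remain the only anchor, so no step beyond the scatter is expected in this assay and no direction can be assigned. The estimated step is an at least 1.1-fold lower number from compound 1 to compound 4 (0.04 log units; that floor lies within the scatter) and it is expected to stay small. The expected value for compound 4 is 120000 nM within an estimated range of 40000 nM to 300000 nM and the assay may well report only a limit.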

Compound 4, half-maximal cytotoxic concentration: 62000 nM
The estimate for compound 4 lay 1.9-fold (0.29 log units) above the measured number; the measured number falls inside the stated range.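

In this assay, for the compounds shown here, ethyl in place of hydrogen on a saturated chain carbon, six bonds along the chain from a triple-bonded carbon, gives the first step that can be read: an at least 2.1-fold lower number from compound 1 to compound 4 (0.33 log units; beyond the scatter). The earlier steps, including those at the 3,4-dihydroxy-5-(hydroxymethyl)oxolan-2-yl group, cannot be read, so this chain position is the only place shown where a change has a readable size and direction. That size is only a floor because compound 1 gives a limit and not a number: the limit of > 133000 nM in this assay, at which 1 of the 4 values shown sits.

Open, on these data alone, is whether a longer chain at this position lowers the number further, or whether an amine or a carboxylic acid in place of the ethyl does the same. Also open, as far as these compounds go, is whether the ethyl change gives a step of like size on compound 2 or compound 3.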